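From Ethylamino to Isopropylamino: An Expected Step

This account rests on a few compounds, and the source may have more. Where it says the series, first, only, none or still open, it means among the compounds named here.

Measured compounds:
compound 1 `CCNc1cc(Oc2ccc(NC(=O)Nc3cccc(C(F)(F)F)c3)cc2)ncn1`, in an assay on isolated protein for inhibition of serine/threonine-protein kinase TNNI3K (Homo sapiens) (on this read-out higher numbers stand for weaker inhibition and lower numbers for stronger inhibition), compound 1 gives 25 nM
compound 2 `CNc1cc(Oc2ccc(NC(=O)Nc3cccc(C(F)(F)F)c3)c(F)c2)ncn1`, in this assay compound 2 gives 63 nM

Compound 1 holds the lowest of the two numbers, and compound 2 sits beyond the scatter above it. The pair differs in more than one place, so no single step can be read from it; the two values only show that compound 1 inhibits more strongly.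

Compound 3 `CC(C)Nc1cc(Oc2ccc(NC(=O)Nc3cccc(C(F)(F)F)c3)cc2)ncn1` has not yet been measured in this assay. Against compound 1 the change is methyl in place of hydrogen on a saturated chain carbon bound to a nitrogen on an aromatic ring and a saturated chain carbon. Among the measured compounds shown here, a single carbon added on the chain of the amino substituent is a modest change, and no measured step speaks to it. The step from compound 1 to compound 3 is expected to be small, a 1.2-fold higher number from compound 1 to compound 3 (0.08 log units; within the scatter), and likely within the scatter in either direction. Compound 3 is therefore estimated at 30 nM, with a range from 10 nM to 100 nM.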

Compound 3, half-maximal inhibitory concentration: 40 nM
For compound 3 the middle estimate is 1.3-fold (0.12 log units) below the measured one, and the stated range covers the measured number.
By their numbers in this assay, from the lowest: compounds 1, 3 and 2 (each within the scatter of the next, the first and the last beyond it).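

In this assay, replacing ethylamino with isopropylamino gives a 1.6-fold higher number from compound 1 to compound 3 (0.20 log units; within the scatter). Among the compounds shown here, this is the first step that can be read at a single place, since compounds 1 and 2 differ in more than one, and it shows that a methyl in place of hydrogen on this saturated chain carbon leaves no difference that can be told from the scatter. Nothing available accounts for the result or shows how the added methyl acts on inhibition.

As far as these compounds go, whether larger groups on the amino nitrogen, such as tert-butyl, cyclopropyl or a longer chain like n-butyl, would also stay within the scatter remains open. So does the effect of a hydroxyl or a carboxylic acid at the end of the chain.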